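Isopropylsulfamoyl in place of methylsulfonyl on the shared core

The source may hold more compounds than are shown below. What is called first, only, known or untested is meant among the compounds shown, and "the series" means these compounds.

Of the compounds shown here, two with a shared core have been measured in an assay on isolated protein for inhibition of phosphatidylinositol 4,5-bisphosphate 3-kinase catalytic subunit beta isoform (Homo sapiens); on this read-out higher numbers stand for weaker inhibition and lower numbers for stronger inhibition. Compound 1 `CCCNS(=O)(=O)c1cncc(-c2ccn3nc(N)nc3c2)c1` carries a propylamino group on the sulfonyl sulfur, and in this assay compound 1 gives 31600000 nM. Compound 2 `CS(=O)(=O)c1cncc(-c2ccn3nc(N)nc3c2)c1` carries a methyl group on the same sulfur, and in this assay compound 2 gives 39800000 nM. Compound 2 stands at the higher of the two numbers, but the step of a 1.3-fold higher number from compound 1 to compound 2 (0.10 log units; within the scatter) is within the scatter, so the two read as equivalent.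

Compound 3 `CC(C)NS(=O)(=O)c1cncc(-c2ccn3nc(N)nc3c2)c1` is not yet measured. Its difference from compound 2 is isopropylamino in place of methyl on a sulfonyl sulfur. Within the data shown here, the only measured step that bears on it is a 1.3-fold higher number from compound 1 to compound 2 (0.10 log units; within the scatter), in which an amino-bearing group on the sulfonyl sulfur and a methyl gave numbers that did not separate beyond the scatter. An isopropylamino group is close in kind to the propylamino group of compound 1, so no step beyond the scatter is expected in this assay.

Compound 3 is therefore expected to give about 32000000 nM, with a range from 10000000 nM to 100000000 nM, which means an expected step of a 1.2-fold lower number from compound 2 to compound 3 (0.09 log units; within the scatter).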

Compound 3, half-maximal inhibitory concentration: 63100000 nM
Compound 3: middle estimate off by 2.0-fold (0.29 log units), on the low side; the measured number falls inside the stated range.
By their numbers in this assay, from the lowest: compounds 1, 2 and 3 (each within the scatter of the next).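

In this assay, the step from methyl to isopropylamino on a sulfonyl sulfur gives a 1.6-fold higher number from compound 2 to compound 3 (0.20 log units; within the scatter) and so stays within the scatter; a second amino-bearing group, with a different chain from that of compound 1, therefore reads as equivalent to methyl at this position. The new compound also allows a comparison that the earlier pair could not offer, a change of chain on the sulfonamide nitrogen itself: isopropyl in place of propyl gives a 2.0-fold higher number from compound 1 to compound 3 (0.30 log units; within the scatter), which is printed as within the scatter, so these two chains cannot be told apart in this read-out. No measurement is available that would explain why none of these three groups separates from the others.

On these data alone, whether an unsubstituted amino group, a morpholine ring, a carboxylic acid or a longer chain on the sulfonyl sulfur would give a step beyond the scatter remains open. The compounds shown also leave open whether any group at this position can move the number in this assay at all, since every change seen so far falls within the scatter.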